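Nitro for Hydrogen on the Phenyl of Compound 3

A few compounds are considered here, and "the series" means these few. Any claim that something is new, unique, unknown or untested is made for them only; others in the source may bear on it.

Measured compounds in a functional assay on the whole organism (integument) for inhibition, with Chilo suppressalis as the target, read by scintillation counting, with a stated time of 72 h; on this read-out higher numbers stand for weaker inhibition and lower numbers for stronger inhibition:
Compound 1, `O=C(Nc1nnc(-c2ccc(Cl)cc2)s1)c1c(Cl)cccc1Cl`, gives 380 nM.
Compound 2, `COc1ccccc1C(=O)Nc1nnc(-c2ccc(Cl)cc2)s1`, gives 53.7 nM.
Compound 3, `COc1cccc(OC)c1C(=O)Nc1nnc(-c2ccccc2)s1`, gives 2950 nM.

Compound 3 stands highest of the three numbers in this assay; its nearest neighbour is compound 1 and its furthest is compound 2, and both gaps lie beyond the scatter, so compound 3 is the weakest inhibitor of the three. Compound 4, `COc1cccc(OC)c1C(=O)Nc1nnc(-c2ccc([N+](=O)[O-])cc2)s1`, differs from compound 3 in one place: nitro in place of hydrogen on an aromatic carbon. Within the data shown here, no measured pair in this set differs by exactly this change, so the step cannot be read off directly. Compounds 1 and 2 both carry a substituent at the same position of that ring and both give lower numbers than compound 3, but they also differ from compound 3 in the other aromatic ring, so the comparison is not clean. A modest downward step, a 2.0-fold lower number from compound 3 to compound 4 (0.29 log units; within the scatter), is expected, with wide uncertainty. Compound 4 is therefore estimated at 1500 nM, within 400 nM to 6000 nM.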

Compound 4, half-maximal inhibitory concentration: 355 nM
Beside the measured number, compound 4's estimate is 4.2-fold (0.63 log units) above it; the whole stated range lies above it.
By their numbers in this assay, from the lowest: compound 2; then compounds 4 and 1 (each within the scatter of the next); then compound 3.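

In this assay, among these compounds, the change from phenyl to 4-nitrophenyl gives an 8.3-fold lower number from compound 3 to compound 4 (0.92 log units; beyond the scatter), the first step in this set that can be read from a single change. The earlier compounds shown here left the effect of this position tangled with differences in the other aromatic ring, whereas this pair shows that, with the rest of compound 3 held fixed, nitro on this aromatic carbon, para to a large group, brings a clear gain in inhibition. Nothing measured here explains the size of this step, and no supporting data bear on it.

From the compounds shown here alone, whether an amine, a nitrile or a carboxylic acid at the same place would lower the number as well remains open. So does whether nitro would give a step of similar size with other substituents on the other aromatic ring.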